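The compounds below may be only part of what the source reports. "The series", "measured", "known", "first", "only" and "open" are said of these compounds alone.

Working notes on the shared core, here the sulfamate carried by three compounds. Compound 3 `CC(C)CCN(CCC(C)C)c1ccc(C(=O)N2CCc3ccc(OS(N)(=O)=O)cc3C2)cc1` holds the highest of the three numbers in an assay on HEK293 cells for inhibition of Steryl-sulfatase (Homo sapiens), tested at 0.1 uM (a lower number here means a weaker effect, a higher number a stronger effect of the compound at the concentration tested), where compound 3 gives 47%. Compound 2 `CCN(Cc1cccnc1)c1ccc(C(=O)N2CCc3ccc(OS(N)(=O)=O)cc3C2)cc1` comes nearest: in this assay compound 2 gives 35.7%, and the step of a number 11.3 percentage points higher from compound 2 to compound 3 (beyond the scatter) lies beyond the scatter. Compound 1 `CN(CCCN1CCCCC1)c1ccc(C(=O)N2CCc3ccc(OS(N)(=O)=O)cc3C2)cc1` stands furthest off: in this assay compound 1 gives 17.4%, with a number 29.6 percentage points higher from compound 1 to compound 3 (beyond the scatter) and a number 18.3 percentage points higher from compound 1 to compound 2 (beyond the scatter) as the two steps that separate it from the others.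

Compound 4 `CN(CCN1CCCCC1)c1ccc(C(=O)N2CCc3ccc(OS(N)(=O)=O)cc3C2)cc1` has not yet been measured. It differs from compound 3 in one place: methyl(2-(piperidin-1-yl)ethyl)amino in place of diisopentylamino on an aromatic carbon. The group that enters is a close relative of the methyl(3-(piperidin-1-yl)propyl)amino group of compound 1, and the step of a number 29.6 percentage points higher from compound 1 to compound 3 (beyond the scatter) is the one that bears most directly on the change, with a number 18.3 percentage points higher from compound 1 to compound 2 (beyond the scatter) showing the same direction away from that kind of group. Running the change in reverse, compound 4 is expected to fall back toward compound 1, so the expected step is a number 27 percentage points lower from compound 3 to compound 4 (beyond the scatter), a drop beyond the scatter. For compound 4 the estimate in this assay is 20%, in the range 6% to 36%.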

Compound 4, a percentage reported as inhibition, at one concentration (the size of the read-out at that concentration, not a potency): 0.3%
The estimate for compound 4 lay 19.7 percentage points above the measured number; measured number below the stated range.
By their numbers in this assay, from the lowest: compound 4; then compound 1; then compound 2; then compound 3.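

In this assay, the new result shows that the length of the chain carrying the piperidine ring matters: piperidin-1-yl in place of (piperidin-1-yl)methyl on a saturated chain carbon gives a number 17.1 percentage points lower from compound 1 to compound 4 (beyond the scatter), so these two close relatives are not interchangeable at this position. For the compounds shown here, the change from the open-chain or pyridine-bearing groups is also larger than the earlier compounds indicated, with a number 46.7 percentage points lower from compound 3 to compound 4 (beyond the scatter) and a number 35.4 percentage points lower from compound 2 to compound 4 (beyond the scatter), which widens the spread seen on this aromatic carbon para to a large group and leaves compound 4 lowest of the four. Nothing available here accounts for these steps.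

Going by these compounds alone, with only two chain lengths in the piperidine-bearing groups, it remains open whether a longer chain, such as a butyl link to the piperidin-1-yl group, would extend the same direction or reverse it. Also open, from the compounds shown here alone, is whether a morpholin-4-yl group in place of the piperidin-1-yl group would shift the read-out at either chain length, and how these differences at a single concentration would translate into potency.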